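This account rests on a few compounds, and the source may have more. Where it says the series, first, only, none or still open, it means among the compounds named here.

Compound 1, `O=C(Nc1cccc(-n2cc(-c3ccncc3)c(-c3cc(O)cc(Cl)c3)n2)c1)Nc1ccc(Cl)c(C(F)(F)F)c1`, stands highest of the two numbers recorded in a functional assay on MOLT-4 cells (Homo sapiens) for inhibition, read by sulforhodamine B assay, with a stated time of 48 h, tested at 0.01 uM (a lower number here means a stronger effect, a higher number a weaker effect of the compound at the concentration tested), where compound 1 gives 100%. Its nearest neighbour, compound 2, `O=C(Nc1cccc(-n2cc(-c3ccncc3)c(-c3cc(O)cc(Cl)c3)n2)c1)Nc1ccc(Cl)c(Cl)c1`, gives 93% in this assay, and the step of a number 7 percentage points lower from compound 1 to compound 2 (within the scatter) lies within the scatter. Compound 3, `COc1cc(Cl)cc(-c2nn(-c3cccc(NC(=O)Nc4ccc(Cl)c(C(F)(F)F)c4)c3)cc2-c2ccncc2)c1`, differs from compound 1 by methyl in place of hydrogen on an oxygen on an aromatic ring. Among the measured compounds shown here, no measured step touches this change; the only step known concerns a different part of the molecule and stayed within the scatter. For compound 3 the expected step is therefore a number 8 percentage points lower from compound 1 to compound 3 (within the scatter), nothing beyond the scatter, and the estimate is 92%, between 65% and 105%.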

Compound 3, a percentage reported as activity, at one concentration (the size of the read-out at that concentration, not a potency): 99%
Estimate against measurement, compound 3: 7 percentage points below, and the stated range covers the measured number.
By their numbers in this assay, from the lowest: compounds 2, 3 and 1 (each within the scatter of the next).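

Methyl on the oxygen of the aromatic ring, turning 3-chloro-5-hydroxyphenyl into 3-chloro-5-methoxyphenyl, gives in this assay a number 1 percentage points lower from compound 1 to compound 3 (within the scatter) and so leaves the number within the scatter. This position therefore tolerates the loss of the hydroxy hydrogen in this read-out, at this one concentration, as the earlier pair, which differed only at the other end of the molecule, could not show. No evidence on hand bears on this result.

Going by these compounds, whether a longer chain such as ethoxy or butoxy on this oxygen, or an amine in place of the hydroxy, would hold the number as well stays open.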